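Demethylation of an Aryl Methyl Ether in a Pyrazole Urea Series

A few compounds are considered here, and "the series" means these few. Any claim that something is new, unique, unknown or untested is made for them only; others in the source may bear on it.

Measured compounds:
- compound 1, `O=C(Nc1cccc(-n2cc(-c3ccncc3)c(-c3ccc(Cl)c(O)c3)n2)c1)Nc1cccc(C(F)(F)F)c1`: 2230 nM
- compound 2, `COc1cc(-c2nn(-c3cccc(NC(=O)Nc4ccc(Cl)c(Cl)c4)c3)cc2-c2ccncc2)ccc1Cl`: 1470 nM

In a functional assay on HOP-92 cells (Homo sapiens) for inhibition, read by sulforhodamine B assay, with a stated time of 48 h (on this read-out lower numbers stand for stronger inhibition of growth and higher numbers for weaker inhibition of growth), compound 2 gives 1470 nM, the lowest of the two numbers, with compound 1 standing close at 2230 nM; that gap lies within the scatter, so the two cannot be ordered. For the measured compounds named here, the two compounds also differ in two places at once, so no single step between them can be read off.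

Compound 3, `O=C(Nc1cccc(-n2cc(-c3ccncc3)c(-c3ccc(Cl)c(O)c3)n2)c1)Nc1ccc(Cl)c(Cl)c1`, has not been measured in this assay. It differs from compound 2 in one place: hydrogen in place of methyl on an oxygen on an aromatic ring, that is methoxy to hydroxy, turning the 4-chloro-3-methoxyphenyl group into 4-chloro-3-hydroxyphenyl. Compound 1 already carries the hydroxy form on the shared core, with a different urea, and it sits within the scatter of compound 2. On that basis no step beyond the scatter is expected in this assay for this change. The step of a 1.1-fold higher number from compound 2 to compound 3 (0.04 log units; within the scatter) is therefore estimated to be small, in either direction. Compound 3 is expected to give about 1600 nM, with a range of 700 nM to 3600 nM.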

Compound 3, concentration for total growth inhibition: 1910 nM
Compound 3: middle estimate off by 1.2-fold (0.08 log units), on the low side, within the range that was stated.
By their numbers in this assay, from the lowest: compounds 2, 3 and 1 (each within the scatter of the next).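

For the compounds shown here, compound 3 gives the first reading of this change on its own, since compound 1 and compound 2 differ in two places at once. In this assay, hydrogen in place of methyl on an oxygen on an aromatic ring, that is methoxy to hydroxy, gives a 1.3-fold higher number from compound 2 to compound 3 (0.11 log units; within the scatter), so the 4-chloro-3-methoxyphenyl and 4-chloro-3-hydroxyphenyl forms cannot be told apart on this read-out. With the hydroxy form held fixed, 3,4-dichlorophenyl in place of 3-(trifluoromethyl)phenyl on an amide-type nitrogen gives a 1.2-fold lower number from compound 1 to compound 3 (0.07 log units; within the scatter), so that change on the urea cannot be told apart either, and no data here offer an explanation for either step.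

The compounds shown leave open whether this position stays as flat with a longer chain on the oxygen, such as ethoxy, or with an amine in place of the hydroxy. They also leave open whether a carboxylic acid on the urea's aryl ring would move the number beyond the scatter, since both aryl groups shown here give values that cannot be ordered.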